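The compounds below may be only part of what the source reports. "The series", "measured", "known", "first", "only" and "open" are said of these compounds alone.

Of the compounds shown here, three of one family have been tested so far, and a fourth awaits its turn. In a functional assay on ACHN cells (Homo sapiens) for inhibition, read by sulforhodamine B assay, with a stated time of 48 h (a higher number here means a weaker inhibitor of growth, a lower number a stronger inhibitor of growth), compound 1 `COc1cc(-c2nn(-c3cccc(NC(=O)Nc4cc(C(F)(F)F)cc(C(F)(F)F)c4)c3)cc2-c2ccncc2)ccc1Cl` gives 491 nM. Compound 3 `O=C(Nc1cccc(-n2cc(-c3ccncc3)c(-c3ccc(Cl)c(O)c3)n2)c1)Nc1ccc(Cl)c(Cl)c1` is a urea like compound 1 but with a different phenyl partner and a hydroxy in place of the methoxy; in this assay compound 3 gives 1040 nM. Compound 2 `COc1cc(-c2nn(-c3cccc(NC(=O)c4cccc(C(F)(F)F)c4)c3)cc2-c2ccncc2)ccc1Cl`, in which the urea is replaced by a plain amide, gives 1890 nM in this assay. That is the largest number of the three; against compound 3 the gap lies within the usual scatter, so nothing can be made of it, while against compound 1 the gap lies beyond the scatter.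

Compound 4 `COc1cc(-c2nn(-c3cccc(NC(=O)Nc4cccc(C(F)(F)F)c4)c3)cc2-c2ccncc2)ccc1Cl` has not yet been measured. It differs from compound 2 in one place: (3-(trifluoromethyl)phenyl)amino in place of 3-(trifluoromethyl)phenyl on a carbonyl carbon. In other words the amide of compound 2 becomes a urea, the same linker that compounds 1 and 3 carry. Among the compounds with values here, no measured pair isolates this single change. Still, since compound 1 with its urea gives 491 nM in this assay, a step downward is expected, and compound 4 is estimated at 800 nM with a likely range from 350 nM to 1800 nM, meaning an expected step of a 2.4-fold lower number from compound 2 to compound 4 (0.37 log units; beyond the scatter) from compound 2 to compound 4.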

Compound 4, concentration for 50% growth inhibition: 656 nM
Estimate against measurement, compound 4: 1.2-fold (0.09 log units) above; the measured number falls inside the stated range.
By their numbers in this assay, from the lowest: compounds 1, 4, 3 and 2 (each within the scatter of the next, the first and the last beyond it).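

Placing (3-(trifluoromethyl)phenyl)amino in place of 3-(trifluoromethyl)phenyl on a carbonyl carbon turns the amide into a urea and brings in one hydrogen-bond donor, and in this assay this gives a 2.9-fold lower number from compound 2 to compound 4 (0.46 log units; beyond the scatter), a modest step, and the first reading of this linker with everything else held the same. The second step, with hydrogen in place of trifluoromethyl on an aromatic carbon, is a 1.3-fold higher number from compound 1 to compound 4 (0.13 log units; within the scatter), so in this assay the two ureas cannot be told apart, and the urea linker with a single trifluoromethyl on its phenyl partner does as well as the one with two within the scatter. Nothing shown here accounts for the step from amide to urea.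

Whether the same step holds with the hydroxy of compound 3 stays open, as compound 3 also has a different phenyl partner and no amide counterpart among these compounds. As far as these compounds go, it is also open how the same place on the carbonyl carbon would respond to an oxygen, giving a carbamate, or to a methylene group, in place of the amino nitrogen of compound 4.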